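This account rests on a few compounds, and the source may have more. Where it says the series, first, only, none or still open, it means among the compounds named here.

Series notes, pyrrole-oxadiazole benzylamines.

Compound 1 `c1ccc(CNC(c2ccc[nH]2)c2nnc(-c3ccccc3)o2)cc1` is the unsubstituted phenyl member. In a functional assay on A549 cells (Homo sapiens) for cytotoxicity, read by MTT assay, with a stated time of 24 h (on this read-out higher numbers stand for weaker inhibition and lower numbers for stronger inhibition), compound 1 gives 187000 nM. Compound 2 `Brc1ccc(-c2nnc(C(NCc3ccccc3)c3ccc[nH]3)o2)cc1` carries bromo in place of hydrogen on an aromatic carbon, and in this assay compound 2 gives 87200 nM. The step of a 2.1-fold lower number from compound 1 to compound 2 (0.33 log units; beyond the scatter) is modest but beyond the scatter. Among the measured compounds shown here, on the two numbers so far, compound 2 stands lowest, with compound 1 as its only neighbour.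

Compound 3 `Cc1cccc(-c2nnc(C(NCc3ccccc3)c3ccc[nH]3)o2)c1` is not yet measured. It differs from compound 2 by 3-methylphenyl in place of 4-bromophenyl on an aromatic carbon. For the measured compounds named here, no measured step covers this exchange: the only step recorded, a 2.1-fold lower number from compound 1 to compound 2 (0.33 log units; beyond the scatter), concerns bromo against hydrogen on the same ring and not a methyl placed elsewhere, so it bears on the new step only loosely. With one substituent swapped for another on the same ring, the expectation is a step near the edge of the scatter, if anything towards a higher number than compound 2.

Compound 3 is therefore expected at 130000 nM, within 55000 nM to 300000 nM. The expected step is a 1.5-fold higher number from compound 2 to compound 3 (0.17 log units; within the scatter).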

Compound 3, half-maximal inhibitory concentration: 431000 nM
Estimate against measurement, compound 3: 3.3-fold (0.52 log units) below; measured number outside the range, above it.
By their numbers in this assay, from the lowest: compound 2; then compound 1; then compound 3.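

In this assay, substitution on the aromatic ring attached to the shared core no longer points one way: methyl in place of hydrogen gives a 2.3-fold higher number from compound 1 to compound 3 (0.36 log units; beyond the scatter), opposite in direction to the bromo step. A substituent on this ring therefore does not lower the number in itself, and compound 3 has the highest number of the three compounds. The exchange of 4-bromophenyl for 3-methylphenyl gives a 4.9-fold higher number from compound 2 to compound 3 (0.69 log units; beyond the scatter), so two groups of equal heavy-atom count on this ring are separated beyond the scatter, although the exchange changes both the group and its place on the ring.

Nothing measured here accounts for the opposite directions of these steps. Still open, from the compounds shown here alone, is whether the separation follows the group or its place, which a bromo group at the place of the methyl in 3-methylphenyl, and a methyl group at the place of the bromo in 4-bromophenyl, would settle, while a methoxy group, an amine or a carboxylic acid on the same ring would show how far the numbers can move in either direction.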